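Swapping an Oxazole for an Oxetane on the Amide Nitrogen

The source may hold more compounds than are shown below. What is called first, only, known or untested is meant among the compounds shown, and "the series" means these compounds.

Compound 2 `Cc1ccc(OCC(=O)N(Cc2cccs2)c2ncco2)cc1` is the most potent of the three measured compounds in an assay on HEK293 cells for agonist activity at transient receptor potential cation channel subfamily M member 8 (Homo sapiens), read by fluorescence and calcium flux, with a stated time of 15 min (a higher number here means that more compound is needed for the effect, a lower number that less compound is needed), where it gives 0.3 nM. Compound 3 `CCc1ccc(OCC(=O)N(CC)Cc2cccs2)cc1` gives 67 nM in this assay, and compound 1 `CCN(Cc1cccs1)C(=O)c1cc2cc(C)ccc2o1` gives 120 nM, both gaps to compound 2 lying well beyond the scatter. Compound 4 `Cc1ccc(OCC(=O)N(Cc2cccs2)C2COC2)cc1` has not yet been measured; it differs from compound 2 by oxetan-3-yl in place of 1,3-oxazol-2-yl on an amide-type nitrogen. Within the data shown here, no directly comparable step exists among the measured compounds, but the two compounds carrying a saturated chain carbon rather than an aromatic ring on the amide-type nitrogen, compound 1 and compound 3, are far weaker than compound 2. A clear loss in this assay is therefore expected, a 130-fold higher number from compound 2 to compound 4 (2.12 log units; beyond the scatter). Compound 4 is estimated at 40 nM, within 5 nM to 300 nM.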

Compound 4, half-maximal effective concentration: 23000 nM
Compound 4: middle estimate off by 580-fold (2.76 log units), on the low side; the measured number lies above the stated range.
By their numbers in this assay, from the lowest: compound 2; then compounds 3 and 1 (each within the scatter of the next); then compound 4.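

At this amide-type nitrogen, oxetan-3-yl in place of 1,3-oxazol-2-yl in this assay gives a 77000-fold higher number from compound 2 to compound 4 (4.88 log units; beyond the scatter) and places compound 4 last of the four compounds. The position therefore does not accept every small ring containing oxygen: here, the one four-membered non-aromatic ring does not match the five-membered aromatic ring. As far as these compounds go, whether a phenyl or a pyridine ring on this nitrogen would keep a number as low as that of compound 2 remains open. No measurement shown accounts for the size of this step.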